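Compound 3 gains a methoxy group

This account rests on a few compounds, and the source may have more. Where it says the series, first, only, none or still open, it means among the compounds named here.

In a functional assay on MOLT-4 cells (Homo sapiens) for antiproliferative activity, read by cell counting, with a stated time of 2 days (on this read-out higher numbers stand for weaker inhibition and lower numbers for stronger inhibition), compound 3 (`COc1ccccc1C(=O)c1sc(Nc2ccccc2)nc1N`) gives 1300 nM, the highest of the three numbers at hand and beyond the scatter from the other two. Compound 1 (`COc1ccc(Nc2nc(N)c(C(=O)c3ccc(Cl)cc3)s2)cc1`) gives 13 nM, and compound 2 (`COc1ccc(Nc2nc(N)c(C(=O)c3ccc(Br)cc3)s2)cc1`) gives 16 nM. Among the measured compounds shown here, the only measured step, a 1.2-fold higher number from compound 1 to compound 2 (0.09 log units; within the scatter), exchanges one halogen for another, lies within the scatter and does not touch the change at issue.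

Compound 4 (`COc1ccc(Nc2nc(N)c(C(=O)c3ccccc3OC)s2)cc1`) differs from compound 3 by methoxy in place of hydrogen on an aromatic carbon, para to a large group, which turns phenyl into 4-methoxyphenyl: methoxy in place of hydrogen on an aromatic carbon. For the measured compounds named here, no measured pair isolates this change. Compound 1, at 13 nM, already carries 4-methoxyphenyl, as does compound 2, at 16 nM, but both also differ from compound 3 in their other aromatic ring. They therefore suggest a lower number, though probably only part of the way towards theirs.

The expected change is a 5.2-fold lower number from compound 3 to compound 4 (0.72 log units; beyond the scatter), towards stronger inhibition. For compound 4 the estimated value is 250 nM, with an expected range of 40 nM to 1300 nM.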

Compound 4, half-maximal inhibitory concentration: 18 nM
For compound 4 the middle estimate is 14-fold (1.14 log units) above the measured one; the whole stated range lies above it.
By their numbers in this assay, from the lowest: compounds 1, 2 and 4 (each within the scatter of the next); then compound 3.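

In this assay, among the compounds shown here, methoxy in place of hydrogen, para to a large group, now has a measured pair of its own, and the step is large and far beyond what the earlier compounds could suggest (a 72-fold lower number from compound 3 to compound 4 (1.86 log units; beyond the scatter)). With 4-methoxyphenyl present, the exchange on the carbonyl carbon leaves the numbers within the scatter, both for 2-methoxyphenyl in place of 4-bromophenyl (a 1.1-fold higher number from compound 2 to compound 4 (0.05 log units; within the scatter)) and for 2-methoxyphenyl in place of 4-chlorophenyl (a 1.4-fold higher number from compound 1 to compound 4 (0.14 log units; within the scatter)). Nothing at hand accounts for the size of the methoxy step.

On these data alone, whether ethoxy, hydroxy, fluoro or a dimethylamino group at this place would give a similar step remains open. So does whether methoxy gives the same step when 4-chlorophenyl stands on the carbonyl carbon.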